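Swapping one bromo for fluoro on a dibromo benzotriazole core

The source may report more compounds than this note shows. Statements on the series, on what has been measured and on what is new or still open speak of the compounds shown alone.

Measured so far:
- compound 1, `Fc1cc(Cl)ccc1-c1ccc(Cn2nnc3ccccc32)cc1`: 1.1 mL/min/g
- compound 2, `Brc1cc(Br)c2nnn(CC3CC3)c2c1`: 15.3 mL/min/g

In an ADME assay on microsomes from liver (Mus musculus, strain NMRI) for metabolic stability, tested at 2.5 uM (a lower number here means slower removal, a higher number faster removal of the compound), compound 2 gives 15.3 mL/min/g, the higher of the two numbers; compound 1 sits far lower, a gap beyond the usual scatter. Compound 3, `Fc1cc(Br)c2nnn(CC3CC3)c2c1`, has not been measured. It differs from compound 2 in one place: fluoro in place of bromo on an aromatic carbon. Among the compounds with values here, no measured pair shows what such a swap does here, so the expected step from compound 2 to compound 3 is a modest fall, a 1.7-fold lower number from compound 2 to compound 3 (0.23 log units; within the scatter), possibly within the scatter. Compound 3 is therefore expected to give about 9 mL/min/g, between 4 mL/min/g and 20 mL/min/g.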

Compound 3, intrinsic clearance in a liver preparation (reported as CLH), per the amount of preparation that the assay uses: 5.7 mL/min/g
Beside the measured number, compound 3's estimate is 1.6-fold (0.20 log units) above it, within the range that was stated.
By their numbers in this assay, from the lowest: compound 1; then compound 3; then compound 2.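

In this assay, fluoro in place of bromo on this aromatic carbon brings a 2.7-fold lower number from compound 2 to compound 3 (0.43 log units; beyond the scatter) and so gives the first measured sign that this single position can change how fast the compound is removed. A swap of one halogen for another is thus enough to move the number by more than repeat measurements would. No measurement shown explains why the number falls with this swap.

On these data alone, what a hydrogen, a nitrile or an amine would do at this position remains open. So does whether the same swap at the remaining bromo would give a similar step.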